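Replacing the hydroxyamino group of a weak cell inhibitor

A few compounds are considered here, and "the series" means these few. Any claim that something is new, unique, unknown or untested is made for them only; others in the source may bear on it.

Measured so far:
Compound 1, `CCC(C)C(NC(=O)NO)C(=O)NC1CCCCC1`: in a functional assay on CCRF-CEM cells (Homo sapiens) for inhibition (on this read-out higher numbers stand for weaker inhibition and lower numbers for stronger inhibition), compound 1 gives 153000 nM.
Compound 2, `CCC(C)C(NC(=O)NO)C(=O)NC(c1ccccc1)c1ccccc1`: in this assay compound 2 gives 107000 nM.

Both compounds share a core and differ only in the group on the amide nitrogen. Their two numbers lie within the usual scatter of repeated measurements of each other, so compound 2 does not stand apart from compound 1 on the numbers shown; both are weak inhibitors.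

Compound 3, `CCC(C)C(NC(=O)n1nnc2ccccc21)C(=O)NC(c1ccccc1)c1ccccc1`, has not yet been measured. It is built from compound 2 by one change: a group of 9 heavy atoms (6 carbon, 3 nitrogen; one five-membered aromatic ring with 3 hetero atoms, one six-membered aromatic ring of carbon only) in place of a group of 2 heavy atoms (1 nitrogen, 1 oxygen; no ring), on a carbonyl carbon. Both hydrogen-bond donors of the leaving group are lost, and three acceptors arrive in their place.

Among the measured compounds shown here, no step between two measured compounds is available here, so nothing about this kind of change has been seen. The expectation for compound 3 is therefore tentative: the change from compound 2 to compound 3 is expected to weaken inhibition, by a 2.3-fold higher number from compound 2 to compound 3 (0.37 log units; beyond the scatter), though a result within the scatter cannot be ruled out. The estimate for compound 3 is 250000 nM, with a range from 60000 nM to 1000000 nM.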

Compound 3, half-maximal inhibitory concentration: 139000 nM
Compound 3: the middle estimate sits 1.8-fold (0.25 log units) above what was measured; the measured number falls inside the stated range.
By their numbers in this assay, from the lowest: compounds 2, 3 and 1 (each within the scatter of the next).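

In this assay, putting the larger group with its five-membered aromatic ring with 3 hetero atoms and its six-membered aromatic ring of carbon only on the carbonyl carbon, in place of hydroxyamino, gives a 1.3-fold higher number from compound 2 to compound 3 (0.11 log units; within the scatter). Among the compounds shown here, this is the first step seen at this place, and it shows that the read-out does not separate the two groups, even though they differ greatly in size and the entering group has no hydrogen-bond donors. For this pair, then, the hydroxyamino group and its donors are not needed to keep the weak inhibition seen with compound 2, although no information is available to explain why this exchange leaves the number within the scatter.

Since compound 2 and compound 3 are both weak inhibitors, this single step cannot show whether other groups on the same carbonyl carbon, such as an amine or a short alkyl chain, would give stronger inhibition, weaker inhibition or a similar number. It also leaves open whether the same exchange would be equally silent with the group that compound 1 carries on its amide nitrogen.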